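A few compounds are considered here, and "the series" means these few. Any claim that something is new, unique, unknown or untested is made for them only; others in the source may bear on it.

Measured so far in an ADME assay on microsomes from liver (Mus musculus) for metabolic stability, with a stated time of 40 min, tested at 10 uM; a higher number here means that more of the compound is left, a lower number that less of the compound is left:
compound 1, `Cn1cc(-c2cc(NS(C)(=O)=O)ccc2Oc2ccc(Br)cc2)n2cncc2c1=O`, gives 61.2%
compound 2, `CCS(=O)(=O)Nc1ccc(Oc2ccc(C(C)C)cc2)c(-c2cn(C)c(=O)c3cncn23)c1`, gives 17.2%
compound 3, `CCS(=O)(=O)Nc1ccc(Oc2ccc(-c3c(C)noc3C)cc2)c(-c2cn(C)c(=O)c3cncn23)c1`, gives 48.2%

Compound 2 stands lowest of the three numbers in this assay; the nearest is compound 3, the furthest compound 1, both beyond the scatter. Going by the values given here, the single measured step that starts from compound 2, a number 31 percentage points higher from compound 2 to compound 3 (beyond the scatter), changes only the group on the aromatic carbon of the outer phenyl ring. Compound 4, `CCS(=O)(=O)Nc1ccc(Oc2cc(C)ccc2F)c(-c2cn(C)c(=O)c3cncn23)c1`, is not yet measured. Its change from compound 2 is 2-fluoro-5-methylphenyl in place of 4-isopropylphenyl on an oxygen on an aromatic ring, or, cut one bond further out, 4-isopropylphenoxy to 2-fluoro-5-methylphenoxy. Among the compounds with values here, no measured step covers this exact change; the step from compound 2 to compound 3 touches the same ring and was large and upward, and compound 1, with a different outer phenyl ring, also stands well above compound 2. An upward step beyond the scatter is therefore expected, though of uncertain size. The expected step is a number 22.8 percentage points higher from compound 2 to compound 4 (beyond the scatter). Compound 4 is estimated at 40%, between 22% and 60%.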

Compound 4, percent of the compound remaining: 4.6%
Compound 4: middle estimate off by 35.4 percentage points, on the high side; the measured number lies below the stated range.
By their numbers in this assay, from the lowest: compound 4; then compound 2; then compound 3; then compound 1.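

In this assay, the exchange at this oxygen gives a number 12.6 percentage points lower from compound 2 to compound 4 (beyond the scatter) and so runs opposite in direction to a number 31 percentage points higher from compound 2 to compound 3 (beyond the scatter) in the same series. Losing 4-isopropylphenyl is therefore not enough in itself to leave more compound; among the compounds shown, the outcome depends on the group that enters, and 2-fluoro-5-methylphenyl goes the wrong way. Nothing available bears on why the number falls here and no cause is assigned.

Going by these compounds alone, the single step changes the ring's substituents together, so the separate contributions of the fluorine, the methyl group and their placement remain unresolved. Also open, as far as these compounds go, is what an outer phenyl ring carrying a morpholine or a carboxylic acid would give in this assay on this core.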